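The source may report more compounds than this note shows. Statements on the series, on what has been measured and on what is new or still open speak of the compounds shown alone.

Compound 1 `CCCCCn1c(N)nc2ccccc21` is the reference point here. In an assay on HEK293 cells for agonist activity at Toll-like receptor 8 (Homo sapiens), read by reporter gene assay (on this read-out higher numbers stand for an effect only at larger amounts of compound and lower numbers for an effect already at smaller amounts), compound 1 gives 3230 nM, and within the usual scatter it cannot be told apart from compound 2 `CCCCCCn1c(N)nc2ccccc21`, which gives 3960 nM, or from compound 3 `CCCCCn1c(N)nc2cc(C)ccc21`, which gives 4570 nM. Compound 4 `CCCCCn1c(N)nc2c(C(F)(F)F)cccc21` differs from compound 1 by trifluoromethyl in place of hydrogen on an aromatic carbon. For the measured compounds named here, the step that bears most on this is the one from compound 1 to compound 3, a methyl on an aromatic carbon, which gave a 1.4-fold higher number from compound 1 to compound 3 (0.15 log units; within the scatter); the chain change gave a 1.2-fold higher number from compound 1 to compound 2 (0.09 log units; within the scatter). Going by the values given here, no measured compound carries a trifluoromethyl group, so its effect is untested. In this assay compound 4 is therefore expected to give 4500 nM, in a range from 1500 nM to 14000 nM, an estimated step of a 1.4-fold higher number from compound 1 to compound 4 (0.14 log units; within the scatter).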

Compound 4, half-maximal effective concentration: "not active" (no number reported)
Compound 4: no number reported; no gap can be computed for the estimate.
By their numbers in this assay, from the lowest: compounds 1, 2 and 3 (each within the scatter of the next).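

For the compounds shown here, compound 4 is reported as not active in this assay without a number, so no step from compound 1 to compound 4 can be read. As far as these compounds go, whether trifluoromethyl elsewhere on the shared core would give a number stays open. No measurement shown bears on this result.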